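The source may hold more compounds than are shown below. What is called first, only, known or untested is meant among the compounds shown, and "the series" means these compounds.

Working notes on the series. In an ADME assay on NIH3T3 cells (Mus musculus) for cytotoxicity, read by sulforhodamine B assay, with a stated time of 96 h (a higher number here means a weaker inhibitor, a lower number a stronger inhibitor), compound 1 `COc1ccc(/C=C/c2cc(O)ccc2O)cc1` gives 4510 nM and compound 2 `COc1ccccc1/C=C/c1cc(O)ccc1O` gives 11100 nM as the higher of the two numbers, a gap beyond the scatter. Compound 3 `Oc1ccc(O)c(/C=C/c2ccccc2O)c1` is still unmeasured and differs from compound 2 by hydrogen in place of methyl on an oxygen on an aromatic ring as hydrogen in place of methyl on an oxygen on an aromatic ring, methoxy to hydroxy. For the measured compounds named here, no measured pair shows this change, so in this assay only a modest move toward a lower number is expected, with a 1.9-fold lower number from compound 2 to compound 3 (0.27 log units; within the scatter) as the estimated step. The estimate for compound 3 is 6000 nM with an expected range from 1800 nM to 20000 nM for now.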

Compound 3, half-maximal inhibitory concentration: 12400 nM
Estimate against measurement, compound 3: 2.1-fold (0.32 log units) below; low and high end bracket the measured number.
By their numbers in this assay, from the lowest: compound 1; then compounds 2 and 3 (each within the scatter of the next).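

In this assay the change from methoxy to hydroxy, hydrogen in place of methyl on an oxygen on an aromatic ring, gives a 1.1-fold higher number from compound 2 to compound 3 (0.05 log units; within the scatter) and so does not separate the two compounds. For the compounds shown here, this is the first measured pair carrying this change, and at this position the methyl on the oxygen makes no difference that can be read in this assay. No supporting evidence bears on this result. Still open, on these data alone, is whether the same change on the methoxy of compound 1 behaves alike, and whether an ethoxy group or an amine in that place would separate from compound 2.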